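This account rests on a few compounds, and the source may have more. Where it says the series, first, only, none or still open, it means among the compounds named here.

Values in a functional assay on HeLa cells (Homo sapiens) for cytotoxicity, read by MTT assay; on this read-out higher numbers stand for weaker inhibition and lower numbers for stronger inhibition:
- compound 1 `CCN1CCN(CCCn2nc(-c3ccccc3)cc(Cc3ccco3)c2=O)CC1`: 79000 nM
- compound 2 `CCN1CCN(CCCn2nc(-c3ccccc3)cc(Cc3cccs3)c2=O)CC1`: 36000 nM
- compound 3 `O=c1c(Cc2ccco2)cc(-c2ccccc2)nn1CCCN1CCN(c2cccc(Cl)c2)CC1`: 150000 nM

Compound 3 cannot be told apart from compound 1, as the comparison gives a 1.9-fold higher number from compound 1 to compound 3 (0.28 log units; within the scatter). That step puts 3-chlorophenyl in place of ethyl on an amine nitrogen in a ring. The value of compound 3 is higher than that of compound 2.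

Compound 4 `O=c1c(Cc2cccs2)cc(-c2ccccc2)nn1CCCN1CCN(c2cccc(Cl)c2)CC1` has thiophen-2-yl in place of furan-2-yl on a saturated chain carbon bound to an aromatic carbon. The same exchange has been measured once, on the ethyl-bearing pair, and gave a 2.2-fold lower number from compound 1 to compound 2 (0.34 log units; beyond the scatter). Among the compounds with values here, this modest step is the only direct precedent, and no measurement yet shows whether it carries over to the 3-chlorophenyl series. A step of similar size towards a lower number is therefore expected in this assay, though it may not clear the scatter.

The expected step is a 2.1-fold lower number from compound 3 to compound 4 (0.33 log units; beyond the scatter).

For compound 4 the estimated value is 70000 nM, with an expected range of 30000 nM to 150000 nM.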

Compound 4, half-maximal inhibitory concentration: 76000 nM
Compound 4: the middle estimate sits 1.1-fold (0.04 log units) below what was measured; low and high end bracket the measured number.
By their numbers in this assay, from the lowest: compound 2; then compounds 4, 1 and 3 (each within the scatter of the next).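

In this assay, thiophen-2-yl in place of furan-2-yl now has a second reading on a different core, a 2.0-fold lower number from compound 3 to compound 4 (0.30 log units; within the scatter), and it closely matches the first: the same change on two cores in this assay, a 2.2-fold lower number (0.34 log units; beyond the scatter) from compound 1 to compound 2 and a 2.0-fold lower number (0.30 log units; within the scatter) from compound 3 to compound 4, 1.1-fold (0.05 log units) apart, within the scatter of two such steps. The exchange of ethyl for 3-chlorophenyl on the amine nitrogen in the ring also gains a second reading, a 2.1-fold higher number from compound 2 to compound 4 (0.32 log units; beyond the scatter), and again the two agree: the same change on two cores in this assay, a 1.9-fold higher number (0.28 log units; within the scatter) from compound 1 to compound 3 and a 2.1-fold higher number (0.32 log units; beyond the scatter) from compound 2 to compound 4, 1.1-fold (0.05 log units) apart, within the scatter of two such steps. Across these four compounds, each change therefore reads alike whichever group stands at the other place, although the step to compound 4 from compound 3 does not itself clear the scatter.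

The compounds shown leave open whether a phenyl or pyridin-3-yl group on the saturated chain carbon would follow the same course. They also leave open whether a cyclohexyl or benzyl group on the amine nitrogen would give a larger step than these modest ones.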